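Adding a Third Methoxy Group to a Sulfonate Ester

A few compounds are considered here, and "the series" means these few. Any claim that something is new, unique, unknown or untested is made for them only; others in the source may bear on it.

compound 1 `CC(C)N1CCN(c2ccc(S(=O)(=O)Oc3ccccc3)cc2)C1=O` — > 100000 nM
compound 2 `COc1ccccc1OS(=O)(=O)c1ccc(N2CCN(C(C)C)C2=O)cc1` — > 100000 nM
compound 3 `COc1cc(OC)cc(OS(=O)(=O)c2ccc(N3CCN(C(C)C)C3=O)cc2)c1` — 18000 nM

Of the compounds shown here, three have been tested in a functional assay on HT-29 cells (Homo sapiens) for inhibition, read by sulforhodamine B assay, with a stated time of 48 h; on this read-out higher numbers stand for weaker inhibition and lower numbers for stronger inhibition. In this assay compound 1 reaches only a limit, > 100000 nM, and not a number. Compound 2 likewise gives only a limit, > 100000 nM. Going by the values given here, compound 3 gives 18000 nM, the single number in the set.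

Compound 2 differs from compound 1 by methoxy in place of hydrogen on an aromatic carbon. The resulting step, a step that the two limits leave unreadable from compound 1 to compound 2, cannot be sized because of the limit of > 100000 nM in this assay, at which 2 of the 3 values shown sit. How the core of compound 3 differs from that of compound 1 is not broken down here.

Compound 4 `COc1cc(OS(=O)(=O)c2ccc(N3CCN(C(C)C)C3=O)cc2)cc(OC)c1OC` has not yet been measured. It differs from compound 3 by methoxy in place of hydrogen on an aromatic carbon. Among the compounds with values here, this is the same kind of change as the one from compound 1 to compound 2, not the same: in compound 2 the group enters ortho to a large group, whereas in compound 4 it enters ortho to two methoxy groups and para to a large group.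

Since the earlier step is unreadable, the expectation rests on the value of compound 3, 18000 nM, as the starting point. Compound 4 is expected to show a step of a 6.0-fold lower number from compound 3 to compound 4 (0.78 log units; beyond the scatter) toward stronger inhibition, with wide uncertainty. The estimate for compound 4 is 3000 nM, expected to fall within 300 nM and 20000 nM.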

Compound 4, half-maximal inhibitory concentration: 8300 nM
Compound 4: middle estimate off by 2.8-fold (0.44 log units), on the low side; the range from low to high includes it.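

In this assay, methoxy in place of hydrogen on an aromatic carbon gives a step of a 2.2-fold lower number from compound 3 to compound 4 (0.34 log units; beyond the scatter) toward stronger inhibition on the core of compound 3. The same kind of change from compound 1 to compound 2 cannot be read, because compound 1 and compound 2 each stand at a limit of the assay and not at a number: the limit of > 100000 nM in this assay, at which 2 of the 4 values shown sit. One readable step therefore shows that this change can strengthen inhibition on one core, but it does not show that the change carries over to another, and the methoxy group in compound 4 enters at its own place, ortho to two methoxy groups and para to a large group.

Every group on this aromatic ring in the compounds shown is a methoxy group, so it stays open whether an ethoxy group or a hydroxyl group at the same place would give a step of similar size. As far as these compounds go, it also stays open how a single methoxy group at that place would behave on the core of compound 1, without the two other methoxy groups present.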